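Dimethoxy series: chloromethyl to (dimethylamino)methyl

A few compounds are considered here, and "the series" means these few. Any claim that something is new, unique, unknown or untested is made for them only; others in the source may bear on it.

Compound 1 `COc1ccc(-c2cc(=O)c3cc(CN(C)C)ccc3o2)cc1` and compound 2 `COc1ccc(-c2cc(=O)c3cc(CCl)ccc3o2)cc1OC` share the core and differ at the saturated chain carbon bound to an aromatic carbon and in the methoxy count. In a functional assay on the whole organism (strain Wistar albino) for inhibition, with Rattus norvegicus as the target, read by paw edema, with stated times of 30 min and 2 h, at a dose of 20 mg/kg by the oral route (on this read-out higher numbers stand for more inhibition at the one dose given (going by the name of the read-out) and lower numbers for less inhibition), compound 1 gives 36%. In this assay compound 2 gives 33.3%, within the scatter of compound 1, so neither can be ranked above the other. Compound 3 `COc1ccc(-c2cc(=O)c3cc(CN(C)C)ccc3o2)cc1OC` is unmeasured; its change from compound 2 is dimethylamino in place of chloro on a saturated chain carbon bound to an aromatic carbon. For the measured compounds named here, no pair of measured compounds isolates this change. The step of a number 1.7 percentage points higher from compound 2 to compound 3 (within the scatter) is expected to stay within the scatter, because compound 1 carries the entering group and gives 36%. Compound 3 is expected to give 35%, within 25% to 46%.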

Compound 3, a percentage reported as inhibition, in the whole organism at one dose (the size of the read-out at that dose, not a potency): 29.8%
Compound 3: the middle estimate sits 5.2 percentage points above what was measured, within the range that was stated.
By their numbers in this assay, from the lowest: compounds 3, 2 and 1 (each within the scatter of the next).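

In this assay the change of chloro to dimethylamino on a saturated chain carbon bound to an aromatic carbon can now be read directly, as a number 3.5 percentage points lower from compound 2 to compound 3 (within the scatter), so the two groups cannot be told apart at this position. The methoxy in place of hydrogen on an aromatic carbon can also be read on its own, as a number 6.2 percentage points lower from compound 1 to compound 3 (within the scatter), and it cannot be told apart from hydrogen either. Nothing measured on these compounds accounts for either step.

On these data alone, it remains open whether a cyclic amine such as morpholine or a carboxylic acid on the same saturated chain carbon would give a step beyond the scatter.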